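The compounds below may be only part of what the source reports. "The series", "measured", "known", "first", "only" and "open" are said of these compounds alone.

Measured compounds:
Compound 1, `CC1=C(C(=O)Nc2ccc(Br)cc2)C(c2ccc(Cl)cc2Cl)N=C(SCc2ccc(Cl)cc2)N1`, gives 39.7% in a functional assay on the whole organism (artery, strain albino) with Rattus norvegicus as the target, with a stated time of 360 min, at a dose of 10 mg/kg by the oral route; on this read-out higher numbers stand for more inhibition at the one dose given (going by the name of the read-out) and lower numbers for less inhibition.
Compound 2, `COc1ccc(C2N=C(SCc3ccccc3)NC(C)=C2C(=O)Nc2ccc(Br)cc2)cc1`, gives 18.6%.
Compound 3, `COc1ccc(C2N=C(SCc3cccc(Cl)c3)NC(C)=C2C(=O)Nc2ccc(Br)cc2)cc1`, gives 39.7%.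

Compound 3 stands level with compound 1 at the digits shown, the two together at the top of the three numbers, and compound 2 lies lowest. Within the data shown here, the one step measured in one place, a number 21.1 percentage points higher from compound 2 to compound 3 (beyond the scatter), adds a chloro to the benzyl group. Compound 4, `COc1ccc(C2N=C(SCc3ccc(Cl)cc3)NC(C)=C2C(=O)Nc2ccc(Br)cc2)cc1`, keeps that chloro but carries 4-chlorophenyl in place of 3-chlorophenyl on a saturated chain carbon bound to a sulfur. Among the measured compounds shown here, no measured step moves a chloro from one ring position to another; compound 1, which also carries the 4-chlorobenzyl group though on a different core, matches compound 3 within the scatter. Compound 4 is therefore expected to change by a number 0.3 percentage points higher from compound 3 to compound 4 (within the scatter), nothing beyond the scatter, and its value is estimated at 40%, between 25% and 55%.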

Compound 4, a percentage reported as inhibition, in the whole organism at one dose (the size of the read-out at that dose, not a potency): 39.2%
For compound 4 the middle estimate is 0.8 percentage points above the measured one, within the range that was stated.
By their numbers in this assay, from the lowest: compound 2; then compounds 4, 1 and 3 (each within the scatter of the next).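

In this assay the chloro shift from 3-chlorophenyl to 4-chlorophenyl on a saturated chain carbon bound to a sulfur gives a number 0.5 percentage points lower from compound 3 to compound 4 (within the scatter) and so leaves the read-out unchanged, while adding this 4-chloro to the benzyl group gives a number 20.6 percentage points higher from compound 2 to compound 4 (beyond the scatter) and matches the gain seen with the 3-chloro. Exchanging 2,4-dichlorophenyl for 4-methoxyphenyl on a saturated ring carbon gives a number 0.5 percentage points lower from compound 1 to compound 4 (within the scatter) and likewise shifts nothing beyond the scatter. Nothing given here explains these results.

On these data alone, whether a bromo or a methoxy in place of the chloro on the benzyl group would hold this level remains open. So does the effect of replacing the benzyl group with a longer chain.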